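The source may report more compounds than this note shows. Statements on the series, on what has been measured and on what is new or still open speak of the compounds shown alone.

Measured compounds:
compound 1, `NS(=O)(=O)c1ccc(Nc2nc3nc(=S)[nH]c(-c4ccccc4)c3s2)cc1`, 333 nM
compound 2, `COc1ccc(-c2[nH]c(=S)nc3nc(Nc4ccc(S(N)(=O)=O)cc4)sc23)cc1`, 667 nM
compound 3, `NS(=O)(=O)c1ccc(Nc2nc3noc(-c4ccccc4)c3s2)cc1`, 669 nM

All three were tested in a functional assay on Caco-2 cells (Homo sapiens) for cytotoxicity, read by MTT assay, with a stated time of 24 h; on this read-out lower numbers stand for stronger inhibition and higher numbers for weaker inhibition. Compound 1 gave 333 nM. Compound 2 gave 667 nM; it differs from compound 1 in one place only, (methoxy in place of hydrogen on an aromatic carbon), and this change brought a 2.0-fold higher number from compound 1 to compound 2 (0.30 log units; within the scatter). Compound 3 gave 669 nM; its core is not the core of compound 1, and the difference between the two cores is not broken down here. The values of compound 3, compound 2 and compound 1 all lie within the scatter of one another, so no order among them can be read from these numbers.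

Compound 4, `COc1ccc(-c2onc3nc(Nc4ccc(S(N)(=O)=O)cc4)sc23)cc1`, has not yet been measured in this assay. It differs from compound 3 by methoxy in place of hydrogen on an aromatic carbon, which is the same change already seen from compound 1 to compound 2, and the place is described in the same words in both cases. On the strength of the earlier step, a 2.0-fold higher number from compound 1 to compound 2 (0.30 log units; within the scatter), the step from compound 3 to compound 4 is expected to be a 1.6-fold higher number from compound 3 to compound 4 (0.22 log units; within the scatter). Compound 4 is therefore estimated at 1100 nM, with a likely range from 500 nM to 2500 nM.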

Compound 4, half-maximal inhibitory concentration: 559 nM
Compound 4: middle estimate off by 2.0-fold (0.29 log units), on the high side, within the range that was stated.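

In this assay, the change from phenyl to 4-methoxyphenyl brought a 1.2-fold lower number from compound 3 to compound 4 (0.08 log units; within the scatter). Set beside the same change on the other core, the two steps cannot be told apart: the same change on two cores in this assay, a 2.0-fold higher number (0.30 log units; within the scatter) from compound 1 to compound 2 and a 1.2-fold lower number (0.08 log units; within the scatter) from compound 3 to compound 4, 2.4-fold (0.38 log units) apart, within the scatter of two such steps. The change can thus be carried between these two cores with no measurable difference in its outcome on this read-out, but both steps lie within the scatter, so neither shows that methoxy moves the number at all, and two cores say nothing about how the change would behave on a further core.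

The compounds shown leave open what other groups would do in the same place, such as a chlorine, a hydroxyl or an amine, and whether any of them would give a step that stands clear of the scatter. They also leave open what would follow if the sulfonamide were replaced by another group, for example a carboxylic acid.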